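Two halogenated phenyl analogues and a third awaiting measurement

The compounds below may be only part of what the source reports. "The series", "measured", "known", "first", "only" and "open" are said of these compounds alone.

Measured so far:
- Compound 1 `OC(CCn1nc2c(Br)c(Br)c(Br)c(Br)c2n1)c1cccc(Cl)c1`: in a functional assay on MCF7 cells (Homo sapiens) for antiproliferative activity, read by MTT assay, with a stated time of 24 h, tested at 12.5 uM (a lower number here means a stronger effect, a higher number a weaker effect of the compound at the concentration tested), compound 1 gives 97%
- Compound 2 `OC(CCn1nc2c(Br)c(Br)c(Br)c(Br)c2n1)c1ccc(Br)cc1`: in this assay compound 2 gives 82%

Among the measured compounds shown here, compound 2 holds the lower of the two numbers recorded in this assay; the only other value belongs to compound 1, which lies higher by a margin outside the scatter. For the measured compounds named here, the one measured step, a number 15 percentage points lower from compound 1 to compound 2 (beyond the scatter), moved the number down, and it involved a change of both the halogen and its position on the phenyl ring.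

Compound 3 `OC(CCn1nc2c(Br)c(Br)c(Br)c(Br)c2n1)c1ccc(Cl)cc1` is the next member: chloro in place of bromo on an aromatic carbon. This is a smaller change than the measured step, since here only the halogen is swapped while its place on the ring is kept. Going by the values given here, no measured step isolates this swap, so the step from compound 1 to compound 2 bears on it only loosely. Compound 3 is therefore expected to stay close to compound 2, with at most a modest rise of a number 6 percentage points higher from compound 2 to compound 3 (within the scatter). The estimate for compound 3 in this assay is 88%, within a range of 75% to 100%.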

Compound 3, a percentage reported as activity, at one concentration (the size of the read-out at that concentration, not a potency): 90%
Compound 3: middle estimate off by 2 percentage points, on the low side; measured number inside the range.
By their numbers in this assay, from the lowest: compounds 2, 3 and 1 (each within the scatter of the next, the first and the last beyond it).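

In this assay the exchange of bromo for chloro on the aromatic carbon para to a large group gives a number 8 percentage points higher from compound 2 to compound 3 (within the scatter) and so cannot be told apart from the scatter of repeated measurements. Among the compounds shown here, the shift from 3-chlorophenyl to 4-chlorophenyl, seen here in isolation for the first time, gives a number 7 percentage points lower from compound 1 to compound 3 (within the scatter) and likewise stays within the scatter, so neither the halogen swap nor the change of ring position is resolved alone, although the earlier step combining both, a number 15 percentage points lower from compound 1 to compound 2 (beyond the scatter), lay beyond it. No measurement at hand bears on the reason for these numbers.

These three compounds leave open whether a group other than a halogen at this same place on the phenyl ring, such as an amine, a carboxylic acid or a methoxy group, would give a step beyond the scatter. They also leave open how the number would respond to a longer chain between the shared core and the phenyl ring, or to the replacement of the hydroxyl group on that chain by an amine.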